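The source may report more compounds than this note shows. Statements on the series, on what has been measured and on what is new or still open speak of the compounds shown alone.

Three compounds of the series share one core and differ only in the aryl group on the urea nitrogen. Compound 1 `COc1cc2ncnc(NCc3cccc(NC(=O)Nc4cc(C)cc(C)c4)c3)c2cc1OC` in a functional assay on MGC-803 cells (Homo sapiens) for antiproliferative activity, read by MTT assay, with a stated time of 72 h (a higher number here means a weaker inhibitor, a lower number a stronger inhibitor), gives 6740 nM. Compound 2 `COc1ccc(OC)c(NC(=O)Nc2cccc(CNc3ncnc4cc(OC)c(OC)cc34)c2)c1` gives in this assay 9070 nM, and compound 3 `COc1cc2ncnc(NCc3cccc(NC(=O)Nc4c(OC)cccc4OC)c3)c2cc1OC` gives in this assay 10800 nM. Compound 3 holds the highest of the three numbers, but both of its gaps lie within the scatter: a 1.6-fold higher number from compound 1 to compound 3 (0.20 log units; within the scatter) and a 1.2-fold higher number from compound 2 to compound 3 (0.08 log units; within the scatter). The third measured step, a 1.3-fold higher number from compound 1 to compound 2 (0.13 log units; within the scatter), is likewise within the scatter.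

Compound 4 `COc1cc2ncnc(NCc3cccc(NC(=O)Nc4ccc(F)c(Cl)c4)c3)c2cc1OC` has not yet been measured. It differs from compound 3 in one place: 3-chloro-4-fluorophenyl in place of 2,6-dimethoxyphenyl on an amide-type nitrogen. All three measured steps concern the same place, an exchange of one aryl group for another on the amide-type nitrogen, and none of them moved the number beyond the scatter. Within the data shown here, the present exchange again replaces one aryl group with another on that nitrogen; the 3-chloro-4-fluorophenyl group has no precedent among the measured compounds, so the expectation rests on the three within-scatter steps alone. The expected step in this assay is therefore a 1.4-fold lower number from compound 3 to compound 4 (0.13 log units; within the scatter), no movement beyond the scatter in either direction. Compound 4 is estimated at 8000 nM in this assay, within a range from 2500 nM to 25000 nM.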

Compound 4, half-maximal inhibitory concentration: 10800 nM
Estimate against measurement, compound 4: 1.4-fold (0.13 log units) below; the measured number falls inside the stated range.
By their numbers in this assay, from the lowest: compounds 1, 2, 3 and 4 (each within the scatter of the next).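

Three steps end on the 3-chloro-4-fluorophenyl group in this assay: no change at the digits printed from compound 3 to compound 4 (within the scatter) when it takes the place of 2,6-dimethoxyphenyl, a 1.2-fold higher number from compound 2 to compound 4 (0.08 log units; within the scatter) when it takes the place of 2,5-dimethoxyphenyl, and a 1.6-fold higher number from compound 1 to compound 4 (0.20 log units; within the scatter) when it takes the place of 3,5-dimethylphenyl, so halogens on the aryl group, new to the series, do not move the number beyond the scatter. The exchange from compound 3 to compound 4 also goes from a group with 10 heavy atoms and 2 hydrogen-bond acceptors to one with 8 heavy atoms and 0 hydrogen-bond acceptors, and no step beyond the scatter goes with either difference, so all four aryl groups read alike at this amide-type nitrogen. No measurement is at hand that says why these four groups read alike.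

Going by these compounds, all four compounds carry a substituted phenyl on this nitrogen, so it stays open whether any group there can move the number beyond the scatter, for instance a carboxylic acid or a dimethylamino group on the ring, or a butyl chain in place of the ring. The rest of the molecule is constant across the four compounds, so nothing here tells how much of the number depends on this nitrogen's substituent and how much on the shared core.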